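Changing the group on the aromatic nitrogen of compound 2

This account rests on a few compounds, and the source may have more. Where it says the series, first, only, none or still open, it means among the compounds named here.

Compound 1 `CNC(=O)Nc1ccc(-c2nc(N3CC4CCC(C3)O4)c3cnn(C(C)C)c3n2)cc1`: 5 nM
Compound 2 `CNC(=O)Nc1ccc(-c2nc(N3CC4CCC(C3)O4)c3cnn(C4CCC5(CC4)OCCCO5)c3n2)cc1`: 8 nM

Both numbers come from a functional assay on LNCaP cells (Homo sapiens) for cytotoxicity; on this read-out higher numbers stand for weaker inhibition and lower numbers for stronger inhibition. Among the compounds with values here, compound 2 stands at 8 nM, within the scatter of compound 1, the only other compound measured. Compound 3 `CNC(=O)Nc1ccc(-c2nc(N3CC4CCC(C3)O4)c3cnn([C@H]4CC[C@@H](OC)CC4)c3n2)cc1` differs from compound 2 in a single place, on an aromatic nitrogen of a five-membered aromatic ring with 2 nitrogen: a group of 8 heavy atoms (7 carbon, 1 oxygen; one six-membered non-aromatic ring of carbon only) in place of a group of 11 heavy atoms (9 carbon, 2 oxygen; one six-membered non-aromatic ring of carbon only, one six-membered non-aromatic ring with 2 hetero atoms), on an aromatic nitrogen. It carries 4-methoxycyclohexyl there. Within the data shown here, one measured step bears on this change, because at this same nitrogen a 1.6-fold higher number from compound 1 to compound 2 (0.20 log units; within the scatter). That exchange of a far smaller group for a far larger one stayed within the scatter, and the entering group keeps the six-membered non-aromatic ring of carbon only. No step beyond the scatter is therefore expected in this assay, in either direction. The estimated step is a 1.3-fold lower number from compound 2 to compound 3 (0.12 log units; within the scatter). For compound 3 the expected value is 6 nM, with an estimated range of 2 nM to 20 nM.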

Compound 3, half-maximal inhibitory concentration: 1 nM
The estimate for compound 3 lay 6.0-fold (0.78 log units) above the measured number, and the stated range ends above it.
By their numbers in this assay, from the lowest: compound 3; then compounds 1 and 2 (each within the scatter of the next).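

Unlike the earlier exchange at this nitrogen, this change moves the number beyond the scatter in this assay: the step is an 8.0-fold lower number from compound 2 to compound 3 (0.90 log units; beyond the scatter), and against the isopropyl compound it is a 5.0-fold lower number from compound 1 to compound 3 (0.70 log units; beyond the scatter). The group on the aromatic nitrogen can therefore shift cytotoxicity in LNCaP cells, and 4-methoxycyclohexyl gives the most potent of the three compounds, while the six-membered ring of carbon only is present in both compound 2 and compound 3 and so does not by itself go with the lower number. No measurement available here explains the difference.

From the compounds shown here alone, it remains open whether a hydroxyl or an amine in place of the methoxy would keep this level. Going by these compounds, the effect of the opposite arrangement at the two stereocentres of the 4-methoxycyclohexyl group also remains open.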